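Shortening the Linker Chain of Compound 2

The compounds below may be only part of what the source reports. "The series", "measured", "known", "first", "only" and "open" are said of these compounds alone.

Three measured compounds share one core and differ mainly in the chain that joins a 2-oxoimidazolidin-1-yl group to an amine nitrogen in a ring. In a functional assay on the whole organism for inhibition, with Rattus norvegicus as the target (on this read-out lower numbers stand for an effect already at smaller amounts and higher numbers for an effect only at larger amounts of compound), compound 1 `O=C1NCCN1CCCCN1CCC(c2cn(-c3ccc(F)cc3)c3ccc(Cl)cc23)CC1` gives only a limit, > 2.2 umol/kg. Compound 2 `O=C1NCCN1CCCCCCN1CCC(c2cn(-c3ccc(F)cc3)c3ccc(Cl)cc23)CC1` likewise reaches only a limit in this assay, > 2.2 umol/kg. The step that the two limits leave unreadable from compound 1 to compound 2 therefore cannot be read in size. Compound 2 thus stands at the limit of > 2.2 umol/kg in this assay, at which 2 of the 3 values shown sit, with no number of its own. Compound 3 `O=C1NCCN1CCN1CCC(c2cn(-c3ccc(F)cc3)c3ccc(C(F)(F)F)cc23)CC1` gives 0.11 umol/kg in this assay; it differs from compound 2 in two places at once, so only the two values can be set side by side, not a single step.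

Compound 4 `O=C1NCCN1CCCN1CCC(c2cn(-c3ccc(F)cc3)c3ccc(Cl)cc23)CC1` differs from compound 2 by 2-oxoimidazolidin-1-yl in place of 3-(2-oxoimidazolidin-1-yl)propyl on a saturated chain carbon, three bonds along the chain from an amine nitrogen in a ring. Going by the values given here, no measured step bears directly on this shortening, since the one step between neighbours, a step that the two limits leave unreadable from compound 1 to compound 2, is unreadable, so neither its direction nor its size can be taken from the data. Leaning on the shorter chain of compound 3 and its value 0.11 umol/kg, compound 4 is expected to fall near 1 umol/kg, within 0.2 umol/kg to 5 umol/kg, which would mean an expected step of an at least 2.2-fold lower number from compound 2 to compound 4 (0.34 log units; beyond the scatter).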

Compound 4, dose for half-maximal effect: 1.8 umol/kg
Beside the measured number, compound 4's estimate is 1.8-fold (0.26 log units) below it; the range from low to high includes it.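

In this assay compound 4 gives 1.8 umol/kg, the only actual number among the compounds shown with chlorine on the shared core. Measured against the limits of the longer chains, the shortening reads as an at least 1.2-fold lower number from compound 2 to compound 4 (0.08 log units; that floor lies within the scatter), and the change of chain also reads as an at least 1.2-fold lower number from compound 1 to compound 4 (0.08 log units; that floor lies within the scatter); both are only floors, so they neither establish a real gain nor fix its size. Compound 2 therefore remains a limit, not a number: the limit of > 2.2 umol/kg in this assay, at which 2 of the 4 values shown sit.

The step between the two longer chains cannot be read, and compound 3, at 0.11 umol/kg, differs from compound 4 in two places, so its value cannot separate chain length from the trifluoromethyl group. Still open, from the compounds shown here alone, is how a shorter chain with chlorine on the core would read, or an amine or a carboxylic acid in place of 2-oxoimidazolidin-1-yl.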